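The source may hold more compounds than are shown below. What is called first, only, known or untested is meant among the compounds shown, and "the series" means these compounds.

Compound 1 `CC(=O)N1CCc2cc(CNC(=O)c3cccs3)ccc21` stands second highest of the three numbers in an assay on HEK293 cells for inhibition of Indoleamine 2,3-dioxygenase 1 (Homo sapiens), tested at 10 uM (a higher number here means more inhibition at the concentration tested (going by the name of the read-out), a lower number less inhibition), where compound 1 gives 72%. Compound 3 `CC(C)CC(=O)N1CCc2cc(CNC(=O)c3cccnc3)ccc21` gives 86%, and compound 2 `CC(C)CC(=O)N1CCc2cc(CNC(=O)C3CC3)ccc21` gives 35%. Among the measured compounds shown here, the one step measured in one place, a number 51 percentage points higher from compound 2 to compound 3 (beyond the scatter), concerns the group on the amide carbonyl, not the acyl chain on the core. Compound 4 `CCC(=O)N1CCc2cc(CNC(=O)c3cccs3)ccc21` differs from compound 1 only by methyl in place of hydrogen on a saturated chain carbon bound to a carbonyl carbon. For the measured compounds named here, no measured step bears on this change, and compounds 1 and 3 differ in two places, so their gap cannot be assigned. Compound 4 is therefore expected to stay close to compound 1, with a step of a number 2 percentage points lower from compound 1 to compound 4 (within the scatter) expected, within the scatter. The estimate for compound 4 is 70%, between 50% and 85%.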

Compound 4, a percentage reported as inhibition, at one concentration (the size of the read-out at that concentration, not a potency): 89%
For compound 4 the middle estimate is 19 percentage points below the measured one; the measured number lies above the stated range.
By their numbers in this assay, from the lowest: compound 2; then compound 1; then compounds 3 and 4 (each within the scatter of the next).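

Acetyl to propanoyl, methyl in place of hydrogen on a saturated chain carbon bound to a carbonyl carbon, gives a number 17 percentage points higher from compound 1 to compound 4 (beyond the scatter) in this assay and so shows that the acyl chain on the core also matters. The earlier step had shown a change only in the group on the amide carbonyl. No evidence bears on the reason for this rise. On these data alone, whether a longer chain or an amine on that chain would change the number further remains open. So does whether the same step holds with pyridin-3-yl or cyclopropyl on the amide carbonyl.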